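Chloro removal on a fused core, transferred to a second series

The source may report more compounds than this note shows. Statements on the series, on what has been measured and on what is new or still open speak of the compounds shown alone.

Measured so far:
compound 1 `ClCc1ccccc1Cn1cnc2c(Cl)nc(Cl)nc21`: 1540 nM
compound 2 `ClCc1ccccc1Cn1cnc2c(Cl)ncnc21`: 2880 nM
compound 3 `ClCc1ccc(Cn2cnc3nc(Cl)nc(Cl)c32)cc1`: 9120 nM

In a functional assay on SK-MEL-5 cells (Homo sapiens) for cytotoxicity, read by sulforhodamine B assay, with a stated time of 48 h (on this read-out higher numbers stand for weaker inhibition of growth and lower numbers for stronger inhibition of growth), compound 1 gives 1540 nM and compound 2 gives 2880 nM. The change between them is hydrogen in place of chloro on an aromatic carbon, and it made a step of a 1.9-fold higher number from compound 1 to compound 2 (0.27 log units; within the scatter). Compound 3 has the same atoms as compound 1 joined differently; the difference between the two cores is not broken down here. In this assay compound 3 gives 9120 nM, beyond the scatter from both compound 1 and compound 2.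

Compound 4 `ClCc1ccc(Cn2cnc3ncnc(Cl)c32)cc1` has not yet been measured. It carries hydrogen in place of chloro on an aromatic carbon, the same change as from compound 1 to compound 2. Compound 4 is expected to follow that earlier step, which rests on a 1.9-fold higher number from compound 1 to compound 2 (0.27 log units; within the scatter), giving an estimated 1.9-fold higher number from compound 3 to compound 4 (0.27 log units; within the scatter). Compound 4 is therefore estimated at 17000 nM, expected between 8000 nM and 40000 nM.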

Compound 4, concentration for total growth inhibition: 12000 nM
The estimate for compound 4 lay 1.4-fold (0.15 log units) above the measured number; low and high end bracket the measured number.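

In this assay, hydrogen in place of chloro on the core of compound 3 gave a 1.3-fold higher number from compound 3 to compound 4 (0.12 log units; within the scatter). Set beside the same exchange on the core of compound 1, the two steps agree: the same change on two cores in this assay, a 1.9-fold higher number (0.27 log units; within the scatter) from compound 1 to compound 2 and a 1.3-fold higher number (0.12 log units; within the scatter) from compound 3 to compound 4, 1.4-fold (0.15 log units) apart, within the scatter of two such steps. This shows that the exchange behaved alike on these two cores, but neither step lies beyond the scatter, so it does not show a real effect of the chloro group on either core, nor how the exchange would behave on any other core.

The compounds shown leave open what an amine or a methoxy group would do in that place. They also leave open whether the chloro group remaining on compound 4 affects growth inhibition.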